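The source may hold more compounds than are shown below. What is called first, only, known or untested is meant among the compounds shown, and "the series" means these compounds.

Compound 3 `CC(C)n1cnc2c(NCc3ccc(C(=O)Nc4ccccc4N)cc3)nc(Cl)nc21` gives 80.5% in a functional assay on NCI-H460 cells (Homo sapiens) for antiproliferative activity, read by CCK-8 assay, with a stated time of 72 h, tested at 8 uM (on this read-out higher numbers stand for a stronger effect at the one concentration tested and lower numbers for a weaker effect), the highest of the three numbers recorded. Compound 1 `CCCCn1cnc2c(NCc3ccc(C(=O)Nc4ccccc4N)cc3)nc(Cl)nc21` gives 23.7% and compound 2 `CCCn1cnc2c(NCc3ccc(C(=O)Nc4ccccc4N)cc3)nc(Cl)nc21` gives 39.2%; the rise is a number 56.8 percentage points higher from compound 1 to compound 3 (beyond the scatter) and a number 41.3 percentage points higher from compound 2 to compound 3 (beyond the scatter), while a number 15.5 percentage points higher from compound 1 to compound 2 (beyond the scatter) is smaller. Compound 4 `Nc1ccccc1NC(=O)c1ccc(CNc2nc(Cl)nc3c2ncn3C2CCCC2)cc1` differs from compound 3 by cyclopentyl in place of isopropyl on an aromatic nitrogen. Both large steps concern a group on that same aromatic nitrogen, yet neither involves a ring, so they only show that this position moves the read-out strongly. A drop within the scatter is expected, a number 8.5 percentage points lower from compound 3 to compound 4 (within the scatter), with wide uncertainty. Compound 4 is therefore estimated at 72%, in the range 40% to 92%.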

Compound 4, a percentage reported as inhibition, at one concentration (the size of the read-out at that concentration, not a potency): 57.4%
For compound 4 the middle estimate is 14.6 percentage points above the measured one; the range from low to high includes it.
By their numbers in this assay, from the lowest: compound 1; then compound 2; then compound 4; then compound 3.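

In this assay, the only ring placed on this aromatic nitrogen, cyclopentyl in place of isopropyl, gives a number 23.1 percentage points lower from compound 3 to compound 4 (beyond the scatter), so branching into a ring does not keep the full read-out. The same ring still outperforms both straight chains, with a number 18.2 percentage points higher from compound 2 to compound 4 (beyond the scatter) and a number 33.7 percentage points higher from compound 1 to compound 4 (beyond the scatter), so the read-out does not simply follow the heavy-atom count of the group across these compounds. Nothing available explains these differences.

The compounds shown leave open where a cyclopropyl or a cyclohexyl ring, or a tert-butyl group, would fall on this nitrogen.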